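This account rests on a few compounds, and the source may have more. Where it says the series, first, only, none or still open, it means among the compounds named here.

Among the measured compounds shown here, compound 2 `Cn1c(=O)c(S(=O)(=O)c2ccc(F)cc2)cc2cnc(Nc3ccc4[nH]ccc4c3)nc21` stands at the lower of the two numbers known in a functional assay on K562 cells (Homo sapiens) for inhibition, read by trypan blue exclusion, with a stated time of 72 h (on this read-out higher numbers stand for weaker inhibition and lower numbers for stronger inhibition), where compound 2 gives 200 nM. For the measured compounds named here, compound 1 `Cn1c(=O)c(S(=O)(=O)Cc2ccc(F)cc2F)cc2cnc(Nc3ccc4[nH]ccc4c3)nc21` gives 1000 nM in this assay, and the single measured step, a 5.0-fold lower number from compound 1 to compound 2 (0.70 log units; beyond the scatter), turns on a different part of the molecule. Compound 3 `Cn1c(=O)c(S(=O)(=O)c2ccc(Br)cc2)cc2cnc(Nc3ccc4[nH]ccc4c3)nc21` differs from compound 2 by bromo in place of fluoro on an aromatic carbon. Going by the values given here, no measured step exchanges one halogen for another on this ring, so no step beyond the scatter is expected: compound 3 is estimated at 200 nM, between 70 nM and 600 nM, a step of no change at the digits printed from compound 2 to compound 3 (within the scatter).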

Compound 3, half-maximal inhibitory concentration: 5000 nM
For compound 3 the middle estimate is 25-fold (1.40 log units) below the measured one, and the stated range ends below it.
By their numbers in this assay, from the lowest: compound 2; then compound 1; then compound 3.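

In this assay, the halogen on this ring proves not to be interchangeable: bromo in place of fluoro, on an aromatic carbon para to a large group, gives a 25-fold higher number from compound 2 to compound 3 (1.40 log units; beyond the scatter). The replacement of 2,4-difluorobenzyl on the sulfonyl sulfur now also runs the other way, with 4-bromophenyl giving a 5.0-fold higher number from compound 1 to compound 3 (0.70 log units; beyond the scatter), against a 5.0-fold lower number from compound 1 to compound 2 (0.70 log units; beyond the scatter) with 4-fluorophenyl. No available evidence accounts for this difference between the two halogens. Where chloro, methyl, methoxy or plain hydrogen at this carbon would fall remains open.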